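Two Epimeric Amide Series in a Cytotoxicity Test

A few compounds are considered here, and "the series" means these few. Any claim that something is new, unique, unknown or untested is made for them only; others in the source may bear on it.

Measured in an ADME assay on HELF cells (Homo sapiens) for cytotoxicity, with a stated time of 3 days; on this read-out lower numbers stand for higher toxicity in this test and higher numbers for lower toxicity in this test:
compound 1 `CC(C)C[C@H](NC(=O)[C@]1(Cc2ccccc2)CCN1C(=O)OCc1ccccc1)C(N)=O` gives 50000 nM
compound 2 `CC(C)CNC(=O)[C@H](C)NC(=O)[C@]1(Cc2ccccc2)CCN1C(=O)OCc1ccccc1` gives > 100000 nM, a limit of the test rather than a number
compound 3 `CC(C)C[C@H](NC(=O)[C@@]1(Cc2ccccc2)CCN1C(=O)OCc1ccccc1)C(N)=O` gives 66000 nM

Compound 1 and compound 3 are built from the same atoms and bonds; their only difference is the two compounds have the same atoms and bonds and differ only in configuration as drawn: 1 of 2 stereo elements differ; a stereocentre at a saturated ring carbon is drawn S in compound 1 and R in compound 3. The resulting step, a 1.3-fold higher number from compound 1 to compound 3 (0.12 log units; within the scatter), sits together with the fact that compounds 1 and 3 differ only in the configuration as drawn as a change that the test does not resolve.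

The second change is 1-(isobutylcarbamoyl)ethyl in place of 1-carbamoyl-3-methylbutyl on an amide-type nitrogen. It produced an at least 2.0-fold higher number from compound 1 to compound 2 (0.30 log units; that floor lies within the scatter), a step whose floor is fixed by the limit of > 100000 nM in this assay, at which 1 of the 3 values shown sits, so its true size is not known. Compound 4 `CC(C)CNC(=O)[C@H](C)NC(=O)[C@@]1(Cc2ccccc2)CCN1C(=O)OCc1ccccc1` carries the same change relative to compound 3, namely (1-(isobutylcarbamoyl)ethyl in place of 1-carbamoyl-3-methylbutyl on an amide-type nitrogen), with the place of the change identical in both pairs.

For compound 4 a step of a 2.0-fold higher number from compound 3 to compound 4 (0.29 log units; within the scatter) in this assay is expected because an at least 2.0-fold higher number from compound 1 to compound 2 (0.30 log units; that floor lies within the scatter). The expectation also rests on the starting point, compound 3, which gives 66000 nM. Compound 4 is therefore estimated at 130000 nM, expected to fall between 60000 nM and 300000 nM, most likely reported only as a limit.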

Compound 4, half-maximal cytotoxic concentration: > 100000 nM
Compound 4 ended at the assay's limit; the forecaster's own chance of this, stated with the estimate: 70%; the middle value lies beyond the limit too.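

In this assay, putting 1-(isobutylcarbamoyl)ethyl in place of 1-carbamoyl-3-methylbutyl on the core of compound 3 gives an at least 1.5-fold higher number from compound 3 to compound 4 (0.18 log units; that floor lies within the scatter), a floor set by a limit of the test rather than a measured size. The change thus takes both epimeric cores to that limit, which shows that the two results are compatible with each other but does not show that the change has the same size on both cores: the same change on two cores in this assay, an at least 2.0-fold higher number (0.30 log units; that floor lies within the scatter) from compound 1 to compound 2 and an at least 1.5-fold higher number (0.18 log units; that floor lies within the scatter) from compound 3 to compound 4; the limit leaves it open whether they differ The step between the two epimers that carry the new group cannot be read, so the data do not show whether configuration at the ring carbon matters once this group is present: the limit of > 100000 nM in this assay, at which 2 of the 4 values shown sit.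

Going by these compounds, what remains open is how far the true values of compound 2 and compound 4 lie beyond the limit, and whether they differ from each other. Also open, on these data alone, is whether a group carrying a carboxylic acid or an amine in place of 1-(isobutylcarbamoyl)ethyl would give a readable number in this assay on either core.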